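This account rests on a few compounds, and the source may have more. Where it says the series, first, only, none or still open, it means among the compounds named here.

Measured compounds:
Compound 1 `Nc1nn(Cc2cn(-c3ccc(O)c([N+](=O)[O-])c3)nn2)c2nc(-c3ccccc3)cc(C(F)(F)F)c12` — 36.3 ug/mL
Compound 2 `Nc1nn(Cc2cn(CC(=O)Nc3ccccc3)nn2)c2nc(-c3ccccc3)cc(C(F)(F)F)c12` — 54.6 ug/mL
Compound 3 `Nc1nn(Cc2cn(CC(=O)Nc3cccc(Cl)c3)nn2)c2nc(-c3ccccc3)cc(C(F)(F)F)c12` — 37 ug/mL

These three share one core and differ only in the group on an aromatic nitrogen. In a functional assay on THP-1 cells (Homo sapiens) for cytotoxicity, read by MTT assay, with a stated time of 24 h (on this read-out lower numbers stand for stronger inhibition and higher numbers for weaker inhibition), compound 1 gives the lowest of the three numbers, though its neighbours sit within the usual scatter: a 1.5-fold higher number from compound 1 to compound 2 (0.18 log units; within the scatter) and a 1.0-fold higher number from compound 1 to compound 3 (0.01 log units; within the scatter). Between the two carbamoylmethyl compounds the step is also small, a 1.5-fold lower number from compound 2 to compound 3 (0.17 log units; within the scatter).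

Compound 4 `Cc1ccc(NC(=O)Cn2cc(Cn3nc(N)c4c(C(F)(F)F)cc(-c5ccccc5)nc43)nn2)cc1` is the next member of this group. Its change from compound 1 is ((4-methylphenyl)carbamoyl)methyl in place of 4-hydroxy-3-nitrophenyl on an aromatic nitrogen. The closest precedents are the steps from compound 1 to compounds 2 and 3, both within scatter, so no step beyond the scatter is expected in this assay. Compound 4 is therefore estimated at 42 ug/mL, with a range of 25 ug/mL to 70 ug/mL, meaning an expected step of a 1.2-fold higher number from compound 1 to compound 4 (0.06 log units; within the scatter).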

Compound 4, half-maximal inhibitory concentration: 41.5 ug/mL
Compound 4: the middle estimate sits 1.0-fold (0.01 log units) above what was measured, and the stated range covers the measured number.
By their numbers in this assay, from the lowest: compounds 1, 3, 4 and 2 (each within the scatter of the next).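

In this assay the ((4-methylphenyl)carbamoyl)methyl group stays within the scatter of all three earlier compounds: replacing 4-hydroxy-3-nitrophenyl gives a 1.1-fold higher number from compound 1 to compound 4 (0.06 log units; within the scatter) and replacing the 3-chlorophenyl gives a 1.1-fold higher number from compound 3 to compound 4 (0.05 log units; within the scatter) while methyl in place of hydrogen gives a 1.3-fold lower number from compound 2 to compound 4 (0.12 log units; within the scatter) in the last comparison. Four different groups on this aromatic nitrogen now give numbers that cannot be told apart, and methyl, like chloro, brings no step beyond the scatter. No measurement shown here offers a reason for this flat picture. Still open, from the compounds shown here alone, is whether an amine or a carboxylic acid on the phenyl ring, or a longer chain before the amide, would give a step beyond the scatter.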